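Swapping a hydroxyphenyl for a dimethylaminophenyl hydrazone

The source may report more compounds than this note shows. Statements on the series, on what has been measured and on what is new or still open speak of the compounds shown alone.

Compound 1, `O=C(N/N=C/c1cccc(F)c1)c1cccnc1Nc1cccc(C(F)(F)F)c1`, gives 58.3%.
Compound 2, `O=C(N/N=C/c1cccc(O)c1)c1cccnc1Nc1cccc(C(F)(F)F)c1`, gives 67.5%.
Compound 3, `O=C(N/N=C/c1ccc(O)cc1)c1cccnc1Nc1cccc(C(F)(F)F)c1`, gives 59.3%.

These three were measured in a functional assay on the whole organism (strain Wistar) for inhibition, with Rattus norvegicus as the target, read by paw edema, with a stated time of 30 min, at a dose of 10 mg/kg by the intraperitoneal route; on this read-out lower numbers stand for less inhibition and higher numbers for more inhibition at the one dose given (going by the name of the read-out). Compound 2 carries the largest of the three numbers, yet the step of a number 9.2 percentage points higher from compound 1 to compound 2 (within the scatter) and the step of a number 8.2 percentage points lower from compound 2 to compound 3 (within the scatter) are both within the scatter, so the three compounds cannot really be told apart on these data. The step of a number 1 percentage points higher from compound 1 to compound 3 (within the scatter) is also within the scatter.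

Compound 4, `CN(C)c1ccc(/C=N/NC(=O)c2cccnc2Nc2cccc(C(F)(F)F)c2)cc1`, has not been measured. It differs from compound 2 in one place: 4-(dimethylamino)phenyl in place of 3-hydroxyphenyl on a carbon with a double bond to nitrogen. Among the compounds with values here, no measured step exchanges one of these groups for the other, so the closest guidance is that every change tried so far at this position stayed within the scatter. On that basis no step beyond the scatter is expected, and the step of a number 7.5 percentage points lower from compound 2 to compound 4 (within the scatter) is my estimate rather than a measurement. For compound 4 the expected value in this assay is 60%, with a range from 45% to 75%.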

Compound 4, a percentage reported as inhibition, in the whole organism at one dose (the size of the read-out at that dose, not a potency): 61.3%
Compound 4: middle estimate off by 1.3 percentage points, on the low side; measured number inside the range.
By their numbers in this assay, from the lowest: compounds 1, 3, 4 and 2 (each within the scatter of the next).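

In this assay, replacing 3-hydroxyphenyl, which has 1 hydrogen-bond donor, with 4-(dimethylamino)phenyl, which has 0, gives a number 6.2 percentage points lower from compound 2 to compound 4 (within the scatter), so among these compounds a hydrogen-bond donor on this ring is not needed to keep the number in the same band. Dimethylamino in place of hydroxy on an aromatic carbon gives a number 2 percentage points higher from compound 3 to compound 4 (within the scatter), and 4-(dimethylamino)phenyl in place of 3-fluorophenyl gives a number 3 percentage points higher from compound 1 to compound 4 (within the scatter), which extends the flat picture at this position to a larger group. Nothing measured here bears on why these groups read alike.

Going by these compounds, it remains open whether any group on this carbon can move the number beyond the scatter, for example a phenyl ring carrying a carboxylic acid, or a saturated alkyl chain in place of the ring. The shown compounds also leave open whether a change elsewhere on the shared core would matter more than one at this position.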